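Cyclopropylcarbamoyl for methoxy on a non-toxic core

The source may hold more compounds than are shown below. What is called first, only, known or untested is meant among the compounds shown, and "the series" means these compounds.

Measured so far in an ADME assay on HeLa cells (Homo sapiens) for cytotoxicity, read by ATP content, with a stated time of 3 days; a higher number here means that more compound is tolerated, a lower number that less compound is tolerated:

Compound 1 `COc1ccc(-n2c(=O)n(Cc3cc4cc(Cl)ccc4n3CCCC#N)c3cnccc32)cc1` gives > 50000 nM, a limit of the assay.
Compound 2 `O=c1n(Cc2cc3cnccc3n2CCCCO)c2cnccc2n1C1CC1` gives > 100000 nM, a limit of the assay.
Compound 3 `O=C(O)CCCn1c(Cn2c(=O)n(C3CC3)c3ccncc32)cc2cc(Cl)ccc21` gives > 50000 nM, a limit of the assay.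

None of the three measured compounds yields a number in this assay. Compound 1 sits at a limit, and the two other values are limits as well: one value sits at the limit of > 100000 nM in this assay, at which 1 of the 3 values shown sits, and two values, compound 1 among them, sit at the limit of > 50000 nM in this assay, at which 2 of the 3 values shown sit. No step between measured compounds differing in one place is available, so nothing beyond the limits themselves can be read from the shown values.

Compound 4 `N#CCCCn1c(Cn2c(=O)n(-c3ccc(C(=O)NC4CC4)cc3)c3ccncc32)cc2cc(Cl)ccc21` is the unmeasured compound. It differs from compound 1 in one place: cyclopropylcarbamoyl in place of methoxy on an aromatic carbon. The cyclopropylcarbamoyl group brings one hydrogen-bond donor and a three-membered non-aromatic ring of carbon only where the methoxy group had none.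

Because all three measured compounds, including compound 1 at the limit of > 50000 nM in this assay, at which 2 of the 3 values shown sit, sit at a limit, the expectation for compound 4 is a step that the limit leaves unreadable from compound 1 to compound 4 of no size beyond the scatter in either direction. Compound 4 is therefore estimated at 80000 nM, within a range from 30000 nM to 200000 nM, most likely reported again only as a limit.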

Compound 4, half-maximal cytotoxic concentration: > 50000 nM
Compound 4 gave a limit, no number; the forecaster's own chance of this, stated with the estimate: 85%; the middle value does not contradict the limit.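

In this assay, for the compounds shown here, compound 1 and compound 4 both give only a limit, so no step between them can be read. The compounds shown leave open how much of any of them is actually tolerated, and whether cyclopropylcarbamoyl in place of methoxy on an aromatic carbon changes that tolerance at all.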